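Ethoxy in place of chloro: compound 3 to compound 4

The source may report more compounds than this note shows. Statements on the series, on what has been measured and on what is new or still open speak of the compounds shown alone.

Three compounds of the series have been run in a functional assay on HepG2 cells (Homo sapiens) for antiproliferative activity, read by MTT assay, with a stated time of 48 h; a lower number here means a stronger inhibitor, a higher number a weaker inhibitor. Compound 1 `N#CC1=C(N)Oc2c(c3nc4ccccc4nc3c3ccccc23)C12C(=O)N(Cc1cnnn1-c1cccc(S(N)(=O)=O)c1)c1ccccc12` gives 21500 nM. Compound 3 `N#CC1=C(N)Oc2c(N)cc3nc4ccccc4nc3c2C12C(=O)N(Cc1cnnn1-c1ccccc1Cl)c1ccccc12` gives 33500 nM, the highest of the two numbers, but compound 1 sits nearest at a gap within the scatter, so no order between the two can be read. For compound 2 `N#CC1=C(N)Oc2c(c3nc4ccccc4nc3c3ccccc23)C12C(=O)N(Cc1cnnn1-c1ccc(Cl)c(Cl)c1)c1ccccc12` only a limit of the assay is reported, > 50000 nM. Among the measured compounds shown here, the single step that can be sized is an at least 2.3-fold higher number from compound 1 to compound 2 (0.36 log units; beyond the scatter); its true extent is open, as the limit of > 50000 nM in this assay, at which 1 of the 3 values shown sits, marks where compound 2 sits.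

Compound 4 `CCOc1ccccc1-n1nncc1CN1C(=O)C2(C(C#N)=C(N)Oc3c(N)cc4nc5ccccc5nc4c32)c2ccccc21` differs from compound 3 by ethoxy in place of chloro on an aromatic carbon; cut one bond further out, the change reads 2-chlorophenyl to 2-ethoxyphenyl. For the measured compounds named here, the one measured step also alters the aryl group on the aromatic nitrogen, and there the entry of chlorines gave a higher number; here a chloro leaves. Going by the values given here, compounds 2 and 3 differ in more than one place, so their pair gives no step of its own. The bearing is therefore weak, and a step within the scatter is expected, if anything toward a lower number, so that a 1.3-fold lower number from compound 3 to compound 4 (0.13 log units; within the scatter) is the estimated shift. Compound 4 is expected to give 25000 nM, within 10000 nM to 60000 nM.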

Compound 4, half-maximal inhibitory concentration: 30500 nM
Estimate against measurement, compound 4: 1.2-fold (0.09 log units) below, within the range that was stated.
By their numbers in this assay, from the lowest: compounds 1, 4 and 3 (each within the scatter of the next). At a limit, above all of these: compound 2.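

In this assay the exchange of chloro for ethoxy on an aromatic carbon, ortho to a large group, gives a 1.1-fold lower number from compound 3 to compound 4 (0.04 log units; within the scatter) and so leaves no readable difference between the two compounds. Among the compounds shown here, the one earlier step concerned the aryl group on the aromatic nitrogen of the core of compound 1, whereas this is the first step read at this position on the core of compound 3, and here 3 heavy atoms with 1 hydrogen-bond acceptor stand in place of a single chlorine with no difference beyond the scatter. Nothing measured in this set gives a reason for this result.

As far as these compounds go, whether an amine, a carboxylic acid or a chain longer than ethoxy at this same position would give a number beyond the scatter of compound 3 remains open. Also open, from the compounds shown here alone, is how the exchange of chloro for ethoxy would read on the core of compound 1, which is not the core of compound 3.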